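The source may report more compounds than this note shows. Statements on the series, on what has been measured and on what is new or still open speak of the compounds shown alone.

Measured so far:
compound 1 `Nc1cc(N)c2nc(-c3ccccc3)c(Oc3ccc(Cl)c(Cl)c3)nc2c1` — < 100000 nM
compound 2 `CCOC(=O)[C@H](CCC(=O)O)NC(=O)c1ccc(CNc2nc3cc(N)cc(N)c3nc2-c2ccccc2)cc1` — < 100000 nM
compound 3 `Nc1cc(N)c2nc(-c3ccccc3)c(NCc3ccc(Cl)c(Cl)c3)nc2c1` — 17400 nM

In a functional assay on CCRF-CEM cells (Homo sapiens) for inhibition, read by sulforhodamine B assay, with a stated time of 48 h (on this read-out higher numbers stand for lower toxicity in this test and lower numbers for higher toxicity in this test), compound 1 reports only a limit, < 100000 nM. Compound 2 likewise reports only a limit, < 100000 nM. Within the data shown here, compound 3 gives 17400 nM, the only number in this assay so far; the other two readings sit at the limit of < 100000 nM in this assay, at which 2 of the 3 values shown sit. Compound 4 `COc1ccc(CNc2nc3cc(N)cc(N)c3nc2-c2ccccc2)cc1OC` is not yet measured in this assay. It differs from compound 3 in one place: 3,4-dimethoxyphenyl in place of 3,4-dichlorophenyl on a saturated chain carbon bound to a nitrogen on an aromatic ring. Among the measured compounds shown here, no measured pair differs in this way, so there is no step to rest on. The expectation is a step no larger than the scatter, with the number for compound 4 perhaps somewhat higher than that of compound 3. Compound 4 is expected to give 25000 nM in this assay, within 9000 nM to 70000 nM, which means an expected step of a 1.4-fold higher number from compound 3 to compound 4 (0.16 log units; within the scatter).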

Compound 4, concentration lethal to 50% of the cells: < 100000 nM
Compound 4 gave a limit, no number; the forecaster's own chance of this, stated with the estimate: 30%; the middle value does not contradict the limit.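

In this assay, among these compounds, compound 4 reports only a limit, < 100000 nM, so no step from compound 3 to compound 4 can be read. Still open is how far 3,4-dimethoxyphenyl in place of 3,4-dichlorophenyl moves the number, and how the compounds held at the limit rank: the limit of < 100000 nM in this assay, at which 3 of the 4 values shown sit.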